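This account rests on a few compounds, and the source may have more. Where it says the series, first, only, none or still open, it means among the compounds named here.

Measured so far:
- compound 1, `O=C1C=C(NC2CCCC2)C(=O)c2c1nc1n2[C@H]2OC[C@@H](O)[C@H]2OC1`: > 8000 nM
- compound 2, `CCCc1ccc(NC2=CC(=O)c3c(nc4n3[C@H]3OC[C@@H](O)[C@H]3OC4)C2=O)cc1`: 1920 nM

Compound 1 carries a cyclopentyl group on the amine nitrogen. In a functional assay on MGC-803 cells (Homo sapiens) for inhibition, read by sulforhodamine B assay (a lower number here means a stronger inhibitor, a higher number a weaker inhibitor), compound 1 gives only a limit, > 8000 nM, and no number is known for it; it stands at the limit of > 8000 nM in this assay, at which 1 of the 2 values shown sits. Compound 2 carries a six-membered aromatic ring on the same amine nitrogen, and in this assay compound 2 gives 1920 nM. Going by the values given here, with one of the two values a limit, no measured step between them can be sized; all that can be said is that compound 1 sits at the limit while compound 2 gives a number inside the range of the assay.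

Compound 3, `COc1cccc(NC2=CC(=O)c3nc4n(c3C2=O)[C@H]2OC[C@@H](O)[C@H]2OC4)c1`, is not yet measured. It differs from compound 1 by 3-methoxyphenyl in place of cyclopentyl on an amine nitrogen. The expectation rests on compound 2, which gives 1920 nM with an aromatic ring on the amine nitrogen. Compound 3 is therefore estimated at 2500 nM in this assay, with a range from 900 nM to 7000 nM. The step of an at least 3.2-fold lower number from compound 1 to compound 3 (0.50 log units; beyond the scatter) is expected to run toward stronger inhibition, beyond the usual scatter, though its exact size cannot be fixed because compound 1 gives only > 8000 nM.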

Compound 3, half-maximal inhibitory concentration: 1780 nM
For compound 3 the middle estimate is 1.4-fold (0.15 log units) above the measured one; low and high end bracket the measured number.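

In this assay, the amine nitrogen now has a step that can be read in one place: 3-methoxyphenyl in place of cyclopentyl gives an at least 4.4-fold lower number from compound 1 to compound 3 (0.65 log units; beyond the scatter). A second aromatic ring on this nitrogen also gives a similar reading, as compound 2 gives 1920 nM and compound 3 gives 1780 nM, two values within the usual scatter of each other, so these two substituted rings cannot be ranked. The size of the step from the cyclopentyl compound remains only a floor, since compound 1 holds a limit and not a number: the limit of > 8000 nM in this assay, at which 1 of the 3 values shown sits.

The compounds shown leave open whether the stronger reading belongs to the aromatic ring itself or depends on what the ring carries, a question that an unsubstituted phenyl group would address. They also leave open how this nitrogen responds to a benzyl group, to a longer alkyl chain, or to a ring carrying an amine or a carboxylic acid.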